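This account rests on a few compounds, and the source may have more. Where it says the series, first, only, none or still open, it means among the compounds named here.

Compound 1 `O=C(NCCCO)c1cnc2ccccc2c1Cl`: in an ADME assay on CCRF-CEM cells (Homo sapiens) for cytotoxicity (a higher number here means that more compound is tolerated, a lower number that less compound is tolerated), compound 1 gives > 100 uM, which is a limit of the assay and not a number.
Compound 2 `C[C@@H](CO)NC(=O)c1cnc2ccccc2c1Cl`: in this assay compound 2 gives > 100 uM, again a limit of the assay.
Compound 3 `COC(=O)CNC(=O)c1cnc2ccccc2c1Cl`: in this assay compound 3 gives > 100 uM, also a limit of the assay.

Where compound 3 stands: it sits at the limit of > 100 uM in this assay, at which 3 of the 3 values shown sit, so nothing separates it from the other two members of the series in this assay. The measured steps bear on this only in a negative way: a step that the two limits leave unreadable from compound 1 to compound 2, a step that the two limits leave unreadable from compound 1 to compound 3 and a step that the two limits leave unreadable from compound 2 to compound 3 are all steps whose size cannot be read, since both ends rest on the limit. No change on the amide-type nitrogen or its attached chain carbon has so far moved any compound off the limit.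

Compound 4 `CC[C@H](C)[C@H](NC(=O)c1cnc2ccccc2c1Cl)C(=O)OC` differs from compound 3 by sec-butyl in place of hydrogen on a saturated chain carbon bound to an amide-type nitrogen and a carbonyl carbon. Among the compounds with values here, the measured steps give no direction for such a change, and no step has been readable; the expectation for compound 4 is therefore that it too remains at or near the limit in this assay, with a number no higher from compound 3 to compound 4 (the limit leaves the size open) as the step this implies. The estimate for compound 4 is 100 uM, in a range from 30 uM to 300 uM, with most of the chance on a limit rather than a number.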

Compound 4, half-maximal toxic concentration: 23.3 uM
The estimate for compound 4 lay 4.3-fold (0.63 log units) above the measured number; the whole stated range lies above it.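

Within the data shown here, replacing hydrogen with sec-butyl on the saturated chain carbon bound to an amide-type nitrogen and a carbonyl carbon gives the first readable step: an at least 4.2-fold lower number from compound 3 to compound 4 (0.63 log units; beyond the scatter). The earlier steps among compound 1, compound 2 and compound 3 cannot be read, so this carbon is the first place shown where a change moves a compound off the limit, and the true size of the step stays open at its upper end since compound 3 rests on that limit. In this assay compound 4 gives 23.3 uM, a number rather than a limit, and it stands alone in that respect: the limit of > 100 uM in this assay, at which 3 of the 4 values shown sit.

One step at one position cannot show whether the drop in tolerated concentration belongs to sec-butyl itself or would follow from any carbon group on that saturated chain carbon, such as methyl, isopropyl or benzyl. It also leaves open whether the number would hold with the opposite arrangement at the defined stereocentres, or with a carboxylic acid in place of the methoxycarbonyl group of compound 4.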